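Demethylation of an aryl methoxy group in a pyrazole series

The compounds below may be only part of what the source reports. "The series", "measured", "known", "first", "only" and "open" are said of these compounds alone.

Measured compounds:
Compound 1 `COc1cc(-c2nn(-c3cccc(NC(=O)c4ccc(Cl)c(C(F)(F)F)c4)c3)cc2-c2ccncc2)ccc1Cl`: 3380 nM
Compound 2 `COc1cc(-c2nn(-c3cccc(NC(=O)Nc4ccc(Cl)c(C(F)(F)F)c4)c3)cc2-c2ccncc2)ccc1Cl`: 1190 nM

Among the compounds with values here, in a functional assay on HT-29 cells (Homo sapiens) for inhibition, read by sulforhodamine B assay, with a stated time of 48 h (a lower number here means a stronger inhibitor of growth, a higher number a weaker inhibitor of growth), compound 2 gives 1190 nM, the lowest of the two numbers; the only neighbour is compound 1, and the change a 2.8-fold lower number from compound 1 to compound 2 (0.45 log units; beyond the scatter) separates them. Compound 3 `O=C(Nc1cccc(-n2cc(-c3ccncc3)c(-c3ccc(Cl)c(O)c3)n2)c1)Nc1ccc(Cl)c(C(F)(F)F)c1` has not been measured. It differs from compound 2 in one place only: hydrogen in place of methyl on an oxygen on an aromatic ring. Seen one bond further out, this is methoxy to hydroxy. Within the data shown here, the single measured step concerns the amide-to-urea change and says nothing about this oxygen; no measured step bears on a methoxy to hydroxy change here, so no direction can be read from the data. The step of a 1.1-fold higher number from compound 2 to compound 3 (0.04 log units; within the scatter) is therefore expected to stay within the usual scatter. Compound 3 is estimated at 1300 nM, in a range from 400 nM to 4200 nM.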

Compound 3, concentration for 50% growth inhibition: 1280 nM
Estimate against measurement, compound 3: 1.0-fold (0.01 log units) above, and the stated range covers the measured number.
By their numbers in this assay, from the lowest: compounds 2 and 3 (each within the scatter of the next); then compound 1.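

In this assay, replacing methoxy with hydroxy on the aromatic ring gives a 1.1-fold higher number from compound 2 to compound 3 (0.03 log units; within the scatter) and so produces no readable difference in growth inhibition. Within the data shown here, this is the first measured information about this oxygen, since the earlier step concerned only the amide-to-urea change: with the urea in place, the methyl on the oxygen can be lost without a detectable effect on the number. No supporting measurement here explains this result.

On these data alone, it remains open whether larger or different groups at this place, such as ethoxy, an amine or a carboxylic acid, would also leave the number unchanged. It is also unknown whether hydroxy would behave the same way in the amide of compound 1, or in cell lines other than the one tested.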